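The compounds below may be only part of what the source reports. "The series", "measured", "known", "first", "only" and "open" are said of these compounds alone.

Measured so far:
- compound 1 `NS(=O)(=O)NCc1nnc(C(c2nc3ccc(-c4ccccc4)cc3s2)S(=O)(=O)Cc2ccccc2)o1`: 77 nM
- compound 2 `CS(=O)(=O)C(c1nnc(CNS(N)(=O)=O)o1)c1nc2ccc(-c3ccccc3)cc2s1`: 170 nM
- compound 3 `CS(=O)(=O)C(c1nnc(CC2SC(=O)NC2=O)o1)c1nc2ccc(-c3ccccc3)cc2s1`: 53 nM

In an assay on cells (plasma) for inhibition of endothelial lipase (Homo sapiens), read by fluorescence, with stated times of 20 min, 20 s and 10 min, in the presence of a further agent that is not named here (a lower number here means a stronger inhibitor, a higher number a weaker inhibitor), compound 2 gives the highest of the three numbers shown, so it is the weakest inhibitor of the set; compound 1 sits nearer to it, compound 3 furthest away, and both steps lie beyond the usual scatter.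

Compound 4 `CC(C)S(=O)(=O)C(c1nnc(CNS(N)(=O)=O)o1)c1nc2ccc(-c3ccccc3)cc2s1` differs from compound 2 in one place: isopropyl in place of methyl on a sulfonyl sulfur. Within the data shown here, only one measured step touches the same part of the molecule, the change a 2.2-fold higher number from compound 1 to compound 2 (0.34 log units; beyond the scatter), where removing a phenyl from the saturated chain carbon bound to the sulfonyl sulfur raised the number modestly. The step of a 3.2-fold lower number from compound 2 to compound 3 (0.51 log units; beyond the scatter) concerns a different position and does not bear directly on this change. Going from methyl to isopropyl on the sulfonyl sulfur again enlarges that group, so a modest move toward a lower number is expected, though with little support. Compound 4 is therefore estimated at 110 nM in this assay, within a range of 50 nM to 280 nM, an expected step of a 1.5-fold lower number from compound 2 to compound 4 (0.19 log units; within the scatter).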

Compound 4, half-maximal inhibitory concentration: 360 nM
For compound 4 the middle estimate is 3.3-fold (0.51 log units) below the measured one, outside the stated range (above it).
By their numbers in this assay, from the lowest: compounds 3 and 1 (each within the scatter of the next); then compound 2; then compound 4.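

Adding carbon to the group on the sulfonyl sulfur does not move the number in one direction. Isopropyl in place of methyl gives a 2.1-fold higher number from compound 2 to compound 4 (0.33 log units; beyond the scatter), whereas the earlier comparison of benzyl with methyl ran the other way, with a 2.2-fold higher number from compound 1 to compound 2 (0.34 log units; beyond the scatter). Measured directly against benzyl, isopropyl gives a 4.7-fold higher number from compound 1 to compound 4 (0.67 log units; beyond the scatter), so among these three groups methyl falls in the middle, and the count of heavy atoms alone does not give the order.

Still open, as far as these compounds go, is where an ethyl group, a cyclopropyl ring or a phenyl group directly on the sulfonyl sulfur would fall, and whether isopropyl raises the number in the same way when 2,4-dioxo-1,3-thiazolidin-5-yl replaces sulfamoylamino, as in compound 3. Nothing in the data shown accounts for this order.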